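The compounds below may be only part of what the source reports. "The series", "measured", "known", "first", "only" and "open" are said of these compounds alone.

Compound 1, with the structure `CC(=O)Nc1ccc(NC(=O)NCCCCC(c2ccc(F)cc2)c2ccc(F)cc2)cc1`, is the starting point. In a functional assay on MDA-MB-231 cells (Homo sapiens) for cytotoxicity, read by MTT assay, with a stated time of 48 h (on this read-out higher numbers stand for weaker inhibition and lower numbers for stronger inhibition), compound 1 gives > 20000 nM, which is a limit of the assay rather than a measured number, as the line the limit of > 20000 nM in this assay, at which 1 of the 3 values shown sits, records. Two measured neighbours carry the same core with a different group on the amide-type nitrogen. Compound 2, with the structure `O=C(NCCCCC(c1ccc(F)cc1)c1ccc(F)cc1)Nc1ccc(C(F)(F)F)cc1`, gives 2780 nM in this assay. Compound 3, with the structure `O=C(NCCCCC(c1ccc(F)cc1)c1ccc(F)cc1)Nc1ccc(Cl)c([N+](=O)[O-])c1`, gives 4060 nM in this assay. Both changes lowered the number: an at least 7.1-fold lower number from compound 1 to compound 2 (0.85 log units; beyond the scatter) and an at least 4.9-fold lower number from compound 1 to compound 3 (0.69 log units; beyond the scatter), while between them a 1.5-fold higher number from compound 2 to compound 3 (0.16 log units; within the scatter).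

Compound 4, with the structure `Cc1ccc(NC(=O)NCCCCC(c2ccc(F)cc2)c2ccc(F)cc2)cc1C`, is not yet measured. Its change from compound 1 is 3,4-dimethylphenyl in place of 4-acetamidophenyl on an amide-type nitrogen. Like the steps to compound 2 and compound 3, this removes the hydrogen-bond donor and acceptor of the acetamido group and puts a group without either in its place, so a step of similar size and direction is expected, roughly an at least 4.0-fold lower number from compound 1 to compound 4 (0.60 log units; beyond the scatter). Compound 4 is therefore estimated at 5000 nM, within a range from 2000 nM to 20000 nM.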

Compound 4, half-maximal inhibitory concentration: > 20000 nM
Compound 4 ended at the assay's limit; the forecaster's own chance of this, stated with the estimate: 20%; middle value at least 4.0-fold (0.60 log units) from the limit.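

Removing the hydrogen-bond donor and acceptor of 4-acetamidophenyl is therefore not enough at this amide-type nitrogen: 3,4-dimethylphenyl carries neither, yet it does not follow the two earlier replacements. The group that enters counts, not only the group that leaves, as this assay shows an at least 4.9-fold higher number from compound 3 to compound 4 (0.69 log units; beyond the scatter) and an at least 7.1-fold higher number from compound 2 to compound 4 (0.85 log units; beyond the scatter) in the comparisons with the measured neighbours. The step from compound 1 to compound 4 cannot be read, since both compounds sit at a limit of the assay: the limit of > 20000 nM in this assay, at which 2 of the 4 values shown sit.

As far as these compounds go, whether a single methyl on the ring would behave like 3,4-dimethylphenyl remains open. So does the outcome with a 4-chlorophenyl, a 4-methoxyphenyl or a ring bearing a carboxylic acid or an amine, any of which could show which feature separates compound 2 and compound 3 from compound 4.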